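From a Carbamoylmethyl Side Chain to Cyclopropylsulfonyl

This account rests on a few compounds, and the source may have more. Where it says the series, first, only, none or still open, it means among the compounds named here.

In an ADME assay on MT4 cells (Homo sapiens) for cytotoxicity, read by MTT assay, with a stated time of 5 days (on this read-out higher numbers stand for lower toxicity in this test and lower numbers for higher toxicity in this test), compound 1 (`Cc1cc(C)cc(S(=O)(=O)c2c(C(=O)N[C@H]3CCNC3)[nH]c3ccc(Cl)cc23)c1`) gives 10000 nM, compound 2 (`Cc1cc(C)cc(S(=O)(=O)c2c(C(=O)N[C@H]3CCN(Cc4ccccc4F)C3)[nH]c3ccc(Cl)cc23)c1`) gives 215000 nM, and compound 3 (`Cc1cc(C)cc(S(=O)(=O)c2c(C(=O)N[C@H]3CCN(CC(N)=O)C3)[nH]c3ccc(Cl)cc23)c1`) gives 28100 nM, the middle of the three numbers. Compound 4 (`Cc1cc(C)cc(S(=O)(=O)c2c(C(=O)NS(=O)(=O)C3CC3)[nH]c3ccc(Cl)cc23)c1`) carries cyclopropylsulfonyl in place of the 1-(carbamoylmethyl)pyrrolidin-3-yl of compound 3 on an amide-type nitrogen: cyclopropylsulfonyl in place of 1-(carbamoylmethyl)pyrrolidin-3-yl on an amide-type nitrogen. The measured steps bear on this change only indirectly, since each alters the substituent on the amine nitrogen in a ring and none removes that ring. The large 22-fold higher number from compound 1 to compound 2 (1.33 log units; beyond the scatter) came with 2-fluorobenzyl, the modest 2.8-fold higher number from compound 1 to compound 3 (0.45 log units; beyond the scatter) with carbamoylmethyl, and the modest 7.7-fold lower number from compound 2 to compound 3 (0.88 log units; beyond the scatter) with the exchange between them. All three measured compounds keep the ring, so the data offer no direction for its loss, and a wide range is warranted. The expected change is a 1.1-fold lower number from compound 3 to compound 4 (0.05 log units; within the scatter), which means no step beyond the scatter in either direction. For compound 4 the estimated value in this assay is 25000 nM, with an expected range of 6000 nM to 120000 nM.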

Compound 4, half-maximal cytotoxic concentration: 147000 nM
For compound 4 the middle estimate is 5.9-fold (0.77 log units) below the measured one; measured number above the stated range.
By their numbers in this assay, from the lowest: compound 1; then compound 3; then compounds 4 and 2 (each within the scatter of the next).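

In this assay, cyclopropylsulfonyl on the amide-type nitrogen gives a 5.2-fold higher number from compound 3 to compound 4 (0.72 log units; beyond the scatter) and a 15-fold higher number from compound 1 to compound 4 (1.17 log units; beyond the scatter), so both changes point to lower toxicity in this test. The earlier compounds shown here varied only the substituent on the amine nitrogen in a ring, whereas compound 4 shows that this position keeps a high number with that ring gone altogether, within the scatter of compound 2. Nothing measured here accounts for the rise.

The compounds shown leave open whether the sulfonyl linkage, the cyclopropyl ring or simply the loss of the pyrrolidine goes with the higher number, as compound 4 changes all of these together. Methylsulfonyl or plain cyclopropyl on the same nitrogen would begin to separate them.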